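Sulfanyl in Place of Chloro on a Shared Nucleoside Core

This account rests on a few compounds, and the source may have more. Where it says the series, first, only, none or still open, it means among the compounds named here.

Measured compounds:
- Compound 1, `C=C1[C@@H](O)[C@H](n2ccc(N)nc2=O)O[C@@H]1CO`, gives 378000 nM in a functional assay on L1210 cells (Mus musculus) for inhibition; a higher number here means a weaker inhibitor, a lower number a stronger inhibitor.
- Compound 2, `C=C1[C@@H](O)[C@H](n2cnc3c(Cl)nc(N)nc32)O[C@@H]1CO`, gives 441000 nM in this assay.
- Compound 3, `C=C1[C@@H](O)[C@H](n2cnc3c(N)nc(N)nc32)O[C@@H]1CO`, reaches only > 200000 nM in this assay, which is a limit of the assay and not a number.

Among the numbers in this assay, compound 2 has the highest of the two; compound 1 is nearest, and the gap between them lies within the usual scatter. Compound 3 sits at the limit of > 200000 nM in this assay, at which 1 of the 3 values shown sits.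

Compound 4, `C=C1[C@@H](O)[C@H](n2cnc3c(S)nc(N)nc32)O[C@@H]1CO`, differs from compound 2 in one place: sulfanyl in place of chloro on an aromatic carbon. For the measured compounds named here, the only measured step at the same place, a step that the limit leaves unreadable from compound 2 to compound 3, ends at a limit and so has no readable size. Going by the values given here, no other measured step touches this position. With nothing readable to lean on, no step beyond the scatter is expected in either direction. Compound 4 is therefore estimated at 400000 nM, with a range from 150000 nM to 1000000 nM. That estimate means an expected step of a 1.1-fold lower number from compound 2 to compound 4 (0.04 log units; within the scatter).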

Compound 4, half-maximal inhibitory concentration: 207000 nM
Compound 4: middle estimate off by 1.9-fold (0.29 log units), on the high side; the range from low to high includes it.
By their numbers in this assay, from the lowest: compounds 4, 1 and 2 (each within the scatter of the next, the first and the last beyond it).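

In this assay, sulfanyl in place of chloro on this aromatic carbon gives a 2.1-fold lower number from compound 2 to compound 4 (0.33 log units; beyond the scatter), the first readable size for any change at this position. It shows that the number can move beyond the scatter when only the group on this carbon changes and the rest of the shared core stays the same. Compound 3 gives a limit and not a number, and the steps that link it to compound 2 and compound 4 therefore cannot be read: the limit of > 200000 nM in this assay, at which 1 of the 4 values shown sits.

One readable step cannot show whether the lower number depends on the sulfur atom or on the hydrogen it carries. A methylsulfanyl, a hydroxyl or a methoxy group on the same carbon could separate those two readings, and a longer alkylsulfanyl chain would test how much room for change this position allows.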